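A Third Aryl Variant on the Shared Core

A few compounds are considered here, and "the series" means these few. Any claim that something is new, unique, unknown or untested is made for them only; others in the source may bear on it.

Measured so far:
compound 1 `COc1ccc(OC)c(/C=N/NC(=O)Nc2ccc(Oc3ccnc(-c4nncn4CCN(C)C)c3)c(F)c2)c1` — 2930 nM
compound 2 `CN(C)CCn1cnnc1-c1cc(Oc2ccc(NC(=O)N/N=C/c3ccc(O)c(F)c3)cc2F)ccn1` — 2620 nM

In a functional assay on NCI-H460 cells (Homo sapiens) for cytotoxicity, read by MTT assay, with a stated time of 72 h (a higher number here means a weaker inhibitor, a lower number a stronger inhibitor), compound 2 gives 2620 nM, and compound 1 gives 2930 nM; the step between them, a 1.1-fold lower number from compound 1 to compound 2 (0.05 log units; within the scatter), is the only one measured at this position. Compound 3 `COc1ccc(/C=N/NC(=O)Nc2ccc(Oc3ccnc(-c4nncn4CCN(C)C)c3)c(F)c2)cc1O` differs from compound 2 in one place: 3-hydroxy-4-methoxyphenyl in place of 3-fluoro-4-hydroxyphenyl on a carbon with a double bond to nitrogen. That earlier swap of the whole aryl group left the number within the scatter, and the present change is of the same kind, so no step beyond the scatter is expected, namely a 1.0-fold higher number from compound 2 to compound 3 (0.01 log units; within the scatter). Compound 3 is therefore estimated at 2700 nM, with a range from 1300 nM to 5600 nM.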

Compound 3, half-maximal inhibitory concentration: 620 nM
Compound 3: the middle estimate sits 4.4-fold (0.64 log units) above what was measured; the measured number lies below the stated range.
By their numbers in this assay, from the lowest: compound 3; then compounds 2 and 1 (each within the scatter of the next).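

Until now, replacing the aryl group on a carbon with a double bond to nitrogen had left the number within the scatter in this assay. The 3-hydroxy-4-methoxyphenyl group gives a 4.2-fold lower number from compound 2 to compound 3 (0.63 log units; beyond the scatter) and also a 4.7-fold lower number from compound 1 to compound 3 (0.67 log units; beyond the scatter) so this position does respond to which aryl group it carries. Nothing available explains why this aryl group stands apart.

Open, as far as these compounds go, is whether the hydroxy group, the methoxy group or the pair accounts for the step. A phenyl carrying only one of them, or carrying an amine or a carboxylic acid instead, would be a further test of this position.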